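Nitro to methyl on compound 2

The source may hold more compounds than are shown below. What is called first, only, known or untested is meant among the compounds shown, and "the series" means these compounds.

Of the compounds shown here, three sharing one core have been read in a functional assay on HeLa cells (Homo sapiens) for inhibition, read by MTT assay, with a stated time of 72 h; a lower number here means a stronger inhibitor, a higher number a weaker inhibitor. Compound 1 (`O=[N+]([O-])c1ccccc1Nc1nnc(-c2c[nH]c3ccccc23)o1`) gives 300 nM, compound 2 (`O=[N+]([O-])c1ccc(Nc2nnc(-c3c[nH]c4ccccc34)o2)cc1`) gives 1760 nM, and compound 3 (`Clc1cccc(Nc2nnc(-c3c[nH]c4ccccc34)o2)c1`) gives 5600 nM. Compound 2 therefore stands in the middle of the three numbers, above compound 1 and below compound 3, with both gaps beyond the scatter.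

Compound 4 (`Cc1ccc(Nc2nnc(-c3c[nH]c4ccccc34)o2)cc1`) is the next to be read. It carries methyl in place of nitro on an aromatic carbon, para to a large group (methyl in place of nitro on an aromatic carbon). Among the compounds with values here, no measured pair isolates a single change, so the expectation rests on little. Within the data shown here, compound 3, the only measured compound without nitro, has the highest number at 5600 nM. A modest rise in the number in this assay is expected, meaning a weaker inhibitor, and its size should lie near the edge of the scatter. The expected step is a 2.3-fold higher number from compound 2 to compound 4 (0.36 log units; beyond the scatter). For compound 4 the estimated value is 4000 nM, with an expected range of 1200 nM to 13000 nM.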

Compound 4, half-maximal inhibitory concentration: 15800 nM
Beside the measured number, compound 4's estimate is 4.0-fold (0.60 log units) below it, outside the stated range (above it).
By their numbers in this assay, from the lowest: compound 1; then compound 2; then compound 3; then compound 4.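

In this assay, within the data shown here, methyl in place of nitro on this aromatic carbon, para to a large group, gives the first single-place change that can be read at this position, and the step is large: a 9.0-fold higher number from compound 2 to compound 4 (0.95 log units; beyond the scatter), well past the rise that compound 3 alone suggested. Compound 4 also lies above its chloro-bearing neighbour, with 4-methylphenyl in place of 3-chlorophenyl on the nitrogen giving a 2.8-fold higher number from compound 3 to compound 4 (0.45 log units; beyond the scatter), so the methyl compound does not match compound 3 even though neither carries nitro. Nothing available explains the size of either step.

As far as these compounds go, it remains open whether the loss comes from removing nitro or from introducing methyl, and hydrogen at this place would separate the two. An amine, a nitrile or a carboxylic acid here would show whether any other group comes close to nitro in this assay.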